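Methoxy to hydroxy: working notes on compound 3

The source may report more compounds than this note shows. Statements on the series, on what has been measured and on what is new or still open speak of the compounds shown alone.

Measured so far in a functional assay on HeLa cells (Homo sapiens) for inhibition, with a stated time of 72 h; on this read-out higher numbers stand for weaker inhibition and lower numbers for stronger inhibition
- compound 1 (`COc1ccccc1-c1ccc(CNc2nc(NC3CCC(N)CC3)nc3c2ncn3C2CCCC2)cc1`) gives 333 nM
- compound 2 (`NC1CCC(Nc2nc(NCc3ccc(-c4ccccc4)nc3)c3ncn(C4CCCC4)c3n2)CC1`) gives 114 nM

Compound 1 holds the higher of the two numbers, which makes it the weaker inhibitor of the pair, and its gap to compound 2 lies beyond the scatter. These two compounds differ in more than one place, so their gap offers no guide to the next step.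

Compound 3 (`NC1CCC(Nc2nc(NCc3ccc(-c4ccccc4O)cc3)c3ncn(C4CCCC4)c3n2)CC1`) carries 2-hydroxyphenyl where compound 1 carries 2-methoxyphenyl, with hydrogen in place of methyl on an oxygen on an aromatic ring. Among the compounds with values here, no measured pair isolates this change, so the expectation is loose. A small step towards a lower number in this assay is expected, close to the scatter, and a result within the scatter would fit as well. The estimate is a 1.7-fold lower number from compound 1 to compound 3 (0.22 log units; within the scatter) and remains an expectation until measured. For compound 3 the expected value is 200 nM with 70 nM to 600 nM as the estimated range.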

Compound 3, half-maximal inhibitory concentration: 4180 nM
Compound 3: the middle estimate sits 21-fold (1.32 log units) below what was measured; measured number above the stated range.
By their numbers in this assay, from the lowest: compound 2; then compound 1; then compound 3.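

In this assay, within the data shown here, the change from methoxy to hydroxy on the 2-methoxyphenyl group is the first one isolated at a single place, and it reads as a 13-fold higher number from compound 1 to compound 3 (1.10 log units; beyond the scatter) with nothing more than a methyl giving way to a hydrogen on that oxygen. This position is therefore sensitive: the loss of one carbon, with no ring and no net charge involved, moves the number well beyond the scatter and towards weaker inhibition, so the hydroxy compound does not stand in for the methoxy compound in this assay. The data shown give no measurement that speaks to the reason for this rise.

From the compounds shown here alone, it remains open whether the rise follows from the new hydrogen on the oxygen or from the missing methyl, as only these two groups appear at this place. Going by these compounds, an ethoxy group, a fluorine atom or an amine in the same place would separate these readings, and the effect of the same change on the compound 2 structure also remains open.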